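Sulfonamide amine variation on the shared core: weak inhibitors

The source may report more compounds than this note shows. Statements on the series, on what has been measured and on what is new or still open speak of the compounds shown alone.

Compound 1 `CCOC(=O)[C@@H]1CCCN(S(=O)(=O)c2ccc(S(=O)(=O)N3CCOCC3)cc2)C1` and compound 2 `CCOC(=O)[C@@H]1CCCN(S(=O)(=O)c2ccc(S(=O)(=O)N3CCNCC3)cc2)C1` differ only in the amine on the sulfonyl sulfur. In a functional assay on MIA PaCa-2 cells (Homo sapiens) for inhibition, read by MTT assay, with a stated time of 7 days (a higher number here means a weaker inhibitor, a lower number a stronger inhibitor), compound 1 gives 23500 nM. In this assay compound 2 gives only a limit, > 30000 nM. Compound 2 thus stands at the limit of > 30000 nM in this assay, at which 1 of the 2 values shown sits. Among the measured compounds shown here, the single measured step, an at least 1.2-fold higher number from compound 1 to compound 2 (0.10 log units; that floor lies within the scatter), is within the scatter. Compound 3 `CCOC(=O)[C@@H]1CCCN(S(=O)(=O)c2ccc(S(=O)(=O)N(C)Cc3ccccc3)cc2)C1` is the next change: benzyl(methyl)amino in place of piperazin-1-yl on a sulfonyl sulfur. For the measured compounds named here, no measured step covers this exchange, so the expected step of an at least 1.2-fold lower number from compound 2 to compound 3 (0.07 log units; that floor lies within the scatter) is taken as none beyond the scatter, with wide uncertainty. Compound 3 is therefore estimated at 25000 nM, in a range from 8000 nM to 80000 nM.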

Compound 3, half-maximal inhibitory concentration: > 30000 nM
Compound 3: no number, only a limit (the forecaster's own chance of this, stated with the estimate: 45%); at least 1.2-fold (0.07 log units) between middle value and limit.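

In this assay, benzyl(methyl)amino in place of morpholin-4-yl on a sulfonyl sulfur gives an at least 1.2-fold higher number from compound 1 to compound 3 (0.10 log units; that floor lies within the scatter), so bringing in a six-membered aromatic ring of carbon only yields no readable gain. The step from compound 2 to compound 3 cannot be read, as both values are limits. Compound 1 remains the only one of the three with a number, and the limit now recurs: the limit of > 30000 nM in this assay, at which 2 of the 3 values shown sit.

Open, on these data alone, is whether another group on the sulfonyl sulfur, such as dimethylamino or a longer chain ending in a carboxylic acid, would give a number rather than a limit. Also open, as far as these compounds go, is whether a change elsewhere on the shared core would do so.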